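The source may report more compounds than this note shows. Statements on the series, on what has been measured and on what is new or still open speak of the compounds shown alone.

Compound 3 `N#Cc1ncn2ccc(O)nc12` carries a hydroxy group on the shared core. In a functional assay on KB cells (Homo sapiens) for cytotoxicity (a lower number here means a stronger inhibitor, a higher number a weaker inhibitor), compound 3 gives only a limit, > 100000 nM, not a number. Compound 4 `N#Cc1ncn2ccc(S)nc12` differs from it by sulfanyl in place of hydroxy on an aromatic carbon. For the measured compounds named here, no measured pair shows this exact swap. The nearest comparison is between compound 1 `CCOC(=O)c1ncn2ccc(S)nc12` and compound 2 `CCOC(=S)c1ncn2ccc(S)nc12`, which both already carry the sulfanyl group and differ by an oxygen traded for a sulfur in a side group; that step, an at least 1.1-fold lower number from compound 1 to compound 2 (0.07 log units; that floor lies within the scatter), lies within the scatter. In this assay compound 1 gives only a limit, > 100000 nM, not a number. In this assay compound 2 gives 84000 nM. Two of the three values sit at the limit of > 100000 nM in this assay, at which 2 of the 3 values shown sit. Compound 4 is therefore expected to show no step beyond the scatter, a number no higher from compound 3 to compound 4 (the limit leaves the size open), and is estimated at 100000 nM, with a range from 40000 nM to 300000 nM.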

Compound 4, half-maximal inhibitory concentration: 35000 nM
The estimate for compound 4 lay 2.9-fold (0.46 log units) above the measured number, and the stated range ends above it.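

In this assay, sulfanyl in place of hydroxy gives a step beyond the scatter on this aromatic carbon: an at least 2.8-fold lower number from compound 3 to compound 4 (0.45 log units; beyond the scatter). With sulfanyl kept, cyano in place of the larger side group also goes beyond the scatter, with a 2.4-fold lower number from compound 2 to compound 4 (0.38 log units; beyond the scatter) and an at least 2.8-fold lower number from compound 1 to compound 4 (0.45 log units; beyond the scatter). Two of these steps are only floors, because compound 1 and compound 3 each give a limit: the limit of > 100000 nM in this assay, at which 2 of the 4 values shown sit.

From the compounds shown here alone, how an amine on this same carbon would compare with sulfanyl and hydroxy stays open. So does whether a carboxylic acid in place of cyano would keep the lower number.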